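The source may report more compounds than this note shows. Statements on the series, on what has been measured and on what is new or still open speak of the compounds shown alone.

Measured compounds:
- compound 1 `Cc1nc(-c2cccs2)sc1COc1ccc2c(c1)OCC2CC(=O)O`: "not determined" (no result reported)
- compound 2 `Cc1ccccc1-c1nc(C)c(COc2ccc3c(c2)OCC3CC(=O)O)s1`: "not determined" (no result reported)
- compound 3 `Cc1cccc(-c2nc(C)c(COc3ccc4c(c3)OCC4CC(=O)O)s2)c1`: 119 nM

Within the data shown here, compound 1 stands without a number in a functional assay on CHO cells for agonist activity at Free fatty acid receptor 1 (Homo sapiens), read by FLIPR and calcium flux; a higher number here means that more compound is needed for the effect, a lower number that less compound is needed; compound 2 likewise carries no result, so the only anchor here is compound 3. In this assay, among the measured compounds shown here, compound 3 gives 119 nM, a single value with no step to any neighbour. Compound 4 `Cc1ccc(-c2nc(C)c(COc3ccc4c(c3)OCC4CC(=O)O)s2)cc1` is the analogue obtained from compound 1 by the change (4-methylphenyl in place of thiophen-2-yl on an aromatic carbon). With compound 1 unmeasured, the size of this step cannot be read off; on its own it is expected to give a compound within the scatter of compound 3, with no clear direction. Compound 4 is therefore estimated at 150 nM, with a range from 40 nM to 600 nM.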

Compound 4, half-maximal effective concentration: 73.5 nM
Estimate against measurement, compound 4: 2.0-fold (0.31 log units) above; the range from low to high includes it.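

In this assay exchanging 3-methylphenyl for 4-methylphenyl on this aromatic carbon gives a 1.6-fold lower number from compound 3 to compound 4 (0.21 log units; within the scatter) and so does not separate the two compounds. Among these compounds, this is the first step that can be read at this position; steps involving compound 1 or compound 2 cannot be read. No measurement at hand bears on this result.

Open, on these data alone, is how thiophen-2-yl compares with 4-methylphenyl here. Also open, as far as these compounds go, is whether an unsubstituted phenyl, a chloro or methoxy group on the phenyl ring, or a pyridine ring in its place would fit this position equally well.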